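The source may hold more compounds than are shown below. What is called first, only, known or untested is meant among the compounds shown, and "the series" means these compounds.

Compound 1 `COc1cccc(OCc2cc(C)nc(-c3ccccn3)n2)c1` is the starting point; in a functional assay on cells for antagonist activity at Free fatty acid receptor 1 (Homo sapiens), read by TR-FRET and inositol phosphate accumulation, with a stated time of 2 h (on this read-out lower numbers stand for stronger inhibition and higher numbers for weaker inhibition), compound 1 gives 2000 nM. Compound 2 `Cc1cc(COc2cccc(F)c2)nc(-c2ccccn2)n1` keeps the shared core and in this assay compound 2 gives 794 nM. Within the data shown here, the single measured step, a 2.5-fold lower number from compound 1 to compound 2 (0.40 log units; beyond the scatter), came from swapping one substituent on the aryl ether side. Among the measured compounds shown here, on the two numbers so far compound 2 stands lowest, with compound 1 as its only neighbour.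

Compound 3 `CCNc1cc(COc2cccc(F)c2)nc(-c2ccccn2)n1` changes a different part of the molecule: ethylamino in place of methyl on an aromatic carbon. For the measured compounds named here, no measured step touches this position, so the one step seen, from the ether side, gives no guide to the size or direction of the change here. The expectation for compound 3 is therefore a step of a 1.0-fold higher number from compound 2 to compound 3 (0.00 log units; within the scatter), that is, no shift beyond the scatter, with a wide range to reflect the lack of evidence. The estimate for compound 3 in this assay is 800 nM, ranging from 250 nM to 2500 nM.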

Compound 3, half-maximal inhibitory concentration: 631 nM
Compound 3: middle estimate off by 1.3-fold (0.10 log units), on the high side; low and high end bracket the measured number.
By their numbers in this assay, from the lowest: compounds 3 and 2 (each within the scatter of the next); then compound 1.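

In this assay, ethylamino in place of methyl on this aromatic carbon gives a 1.3-fold lower number from compound 2 to compound 3 (0.10 log units; within the scatter), so the two compounds cannot be told apart. Among these compounds, the earlier compounds differed only on the aryl ether side, and this step is the first to show that a group with more heavy atoms, plus a hydrogen-bond donor and acceptor, can sit at this position without a shift beyond the scatter. No measurement at hand explains why the two groups read alike.

As far as these compounds go, this one step does not separate the effect of the added nitrogen from that of the longer chain, so how a methylamino, dimethylamino or propyl group would read at this position stays open. Also open, from the compounds shown here alone, is whether ethylamino would read the same with methoxy, as in compound 1, on the aryl ether side.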